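The source may report more compounds than this note shows. Statements on the series, on what has been measured and on what is new or still open speak of the compounds shown alone.

Compound 2 `CS(=O)(=O)c1ccc(-c2[nH]c(Br)cc2-c2ccc(F)cc2)cc1` is one of two pyrroles measured in a functional assay on the whole organism with Rattus norvegicus as the target; a higher number here means that more compound is needed for the effect, a lower number that less compound is needed. In this assay compound 2 gives 2.66 uM, the lower of the two numbers; compound 1 `CS(=O)(=O)c1ccc(-c2[nH]c(Cl)c(Cl)c2-c2ccc(F)cc2)cc1` gives 3.9 uM, and the gap between compound 1 and compound 2 lies within the scatter, so neither is set apart from the other. The next compound, compound 3 `CS(=O)(=O)c1ccc(-c2[nH]c(Cl)cc2-c2ccc(F)cc2)cc1`, carries chloro in place of bromo on an aromatic carbon. Among the measured compounds shown here, since no measured pair shows this exchange, the step is expected to be small, from compound 2 to compound 3 a 1.2-fold higher number from compound 2 to compound 3 (0.08 log units; within the scatter), with no change beyond the scatter. Compound 3 is therefore estimated at 3.2 uM, with a range from 1.3 uM to 8 uM.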

Compound 3, concentration for half-maximal effect: 1.43 uM
Beside the measured number, compound 3's estimate is 2.2-fold (0.35 log units) above it, and the stated range covers the measured number.
By their numbers in this assay, from the lowest: compounds 3, 2 and 1 (each within the scatter of the next, the first and the last beyond it).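

In this assay, the exchange of bromo for chloro on this aromatic carbon gives a 1.9-fold lower number from compound 2 to compound 3 (0.27 log units; within the scatter), so this pair does not separate the two halogens at this position. The other change, hydrogen in place of chloro on an aromatic carbon, gives a 2.7-fold lower number from compound 1 to compound 3 (0.44 log units; beyond the scatter), a modest step and the only one here that exceeds the scatter. The compounds shown leave open how a methyl, a nitrile or an amine would read on the carbon that holds bromo or chloro. No measurement shown here explains either step.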